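The source may report more compounds than this note shows. Statements on the series, on what has been measured and on what is new or still open speak of the compounds shown alone.

Series notes. Compound 1 `Cc1cc(-c2nc(-c3ccc(CCC(=O)O)cc3C)no2)ccc1OC(C)C`, compound 2 `Cc1cc(CCC(=O)O)ccc1-c1noc(-c2ccc(OC(C)C)c(C#N)c2)n1`, compound 3 `Cc1cc(CCC(=O)O)ccc1-c1noc(-c2ccc(OC(C)C(F)(F)F)c(C#N)c2)n1` and the unmeasured compound 4 `Cc1cc(CCC(=O)O)ccc1-c1noc(-c2ccc(OCC(F)(F)F)c(C#N)c2)n1` share one core. In a functional assay on CHO cells with sphingosine 1-phosphate receptor 4 (Homo sapiens) as the target, read by GTPgammaS binding (a higher number here means that more compound is needed for the effect, a lower number that less compound is needed), compound 1 reaches only the assay limit, > 10000 nM. In this assay compound 2 likewise stops at the limit, > 10000 nM. Compound 3 too gives only a limit in this assay, > 10000 nM. The recorded steps are a step that the two limits leave unreadable from compound 1 to compound 2 and a step that the two limits leave unreadable from compound 2 to compound 3; all three values sit at the limit of > 10000 nM in this assay, at which 3 of the 3 values shown sit. Compound 4 differs from compound 3 by hydrogen in place of methyl on a saturated chain carbon bound to an oxygen on an aromatic ring and a saturated chain carbon. For the measured compounds named here, no measured step bears on this change with a readable size, so no shift beyond the scatter can be read from the series, and a step that the limit leaves unreadable from compound 3 to compound 4 is expected. Compound 4 is estimated at 20000 nM in this assay, between 5000 nM and 100000 nM, most likely again as a limit.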

Compound 4, half-maximal effective concentration: > 10000 nM
Compound 4 gave a limit, no number; the forecaster's own chance of this, stated with the estimate: 85%; the middle value does not contradict the limit.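

In this assay, for the compounds shown here, compound 4 gives > 10000 nM, a limit and not a number, so no step from compound 2 or compound 3 to compound 4 can be read. The compounds shown leave open how far any of these changes shifts the half-maximal effective concentration, with every value at one limit: the limit of > 10000 nM in this assay, at which 4 of the 4 values shown sit.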